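A few compounds are considered here, and "the series" means these few. Any claim that something is new, unique, unknown or untested is made for them only; others in the source may bear on it.

Measured so far:
- compound 1 `O=C(CCCCCCCc1ccccc1)C(F)(F)F`: 2000 nM
- compound 2 `O=C(CCCCCc1ccccc1)C(F)(F)F`: 5000 nM

Both numbers come from an assay on isolated protein for inhibition of Fatty-acid amide hydrolase 1 (Homo sapiens), read by radioligand binding; on this read-out higher numbers stand for weaker inhibition and lower numbers for stronger inhibition. Among the compounds with values here, compound 1 stands at the lowest of the two numbers in this assay, and the step up to compound 2 lies beyond the scatter, so on these two entries compound 1 is the stronger inhibitor; the two share the trifluoromethyl ketone and differ only in chain length, and no further pair is available for comparison.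

Compound 3 `CCCCCCCCCC(=O)C(F)(F)F` has not been measured in this assay. Its difference from compound 1 is ethyl in place of phenyl on a saturated chain carbon, seven bonds along the chain from a carbonyl carbon. Within the data shown here, the phenyl that leaves is the only ring in compound 1, and the entering ethyl continues the saturated chain instead. Among the measured compounds shown here, nothing among the measured entries shows what this exchange does, so the expectation must be broad.

The step from compound 1 to compound 3 is expected to be a 1.5-fold higher number from compound 1 to compound 3 (0.18 log units; within the scatter), that is, no change that clearly passes the scatter, with a slight lean toward weaker inhibition.

Compound 3 is therefore estimated at 3000 nM in this assay, within a range from 1000 nM to 10000 nM.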

Compound 3, half-maximal inhibitory concentration: 10000 nM
Compound 3: middle estimate off by 3.3-fold (0.52 log units), on the low side; the range from low to high includes it.
By their numbers in this assay, from the lowest: compound 1; then compounds 2 and 3 (each within the scatter of the next).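

In this assay, ethyl in place of phenyl on a saturated chain carbon, seven bonds along the chain from a carbonyl carbon, gives a 5.0-fold higher number from compound 1 to compound 3 (0.70 log units; beyond the scatter) and so weakens inhibition by more than the scatter. Within the data shown here, this is the first step that changes the phenyl rather than the chain length, and it shows that at this place the only ring in compound 1 cannot be exchanged for ethyl without a loss of inhibition. The pair fixes the direction and size of this one exchange, but no measurement at hand bears on why the number rises.

The compounds shown leave open whether the phenyl matters as an aromatic ring or simply as a ring, a question that a cyclohexyl group at the same place would address. They also leave open how a pyridine ring, or a substituent such as fluorine or methoxy on the phenyl, would compare with compound 1, and whether a longer chain ending in phenyl would take the number lower still.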